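Fluoro in place of methoxy on compound 1

The compounds below may be only part of what the source reports. "The series", "measured", "known", "first", "only" and "open" are said of these compounds alone.

Among the compounds with values here, in a functional assay on MGC-803 cells (Homo sapiens) for antiproliferative activity, read by MTT assay, with a stated time of 72 h (on this read-out higher numbers stand for weaker inhibition and lower numbers for stronger inhibition), compound 1 (`COc1ccc(-n2nc(-c3ccccc3)nc2CNc2ccc(C(=O)NO)cc2)cc1`) gives 7050 nM as the only exact number so far. Compound 2 (`COc1ccc(-n2nc(-c3ccc(O)cc3)nc2CNc2ccc(C(=O)NO)cc2)cc1`) reads > 20000 nM and that is a limit of the assay, not a number. Compound 3 (`O=C(NO)c1ccc(NCc2nc(-c3ccccc3)nn2-c2ccc(F)cc2)cc1`) has not yet been measured. It keeps the core of compound 1 and carries fluoro in place of methoxy on an aromatic carbon, para to a large group (fluoro in place of methoxy on an aromatic carbon). Within the data shown here, the one measured step is an at least 2.8-fold higher number from compound 1 to compound 2 (0.45 log units; beyond the scatter) and it lies beyond the scatter, but it comes from hydroxy in place of hydrogen on an aromatic carbon at another place, so it says little about this exchange. Among the measured compounds shown here, no measured step covers the loss of methoxy. The data therefore give no direction, and no step beyond the scatter is expected in this assay for this change. The expectation rests on compound 1 at 7050 nM alone. The estimated step is a 1.1-fold lower number from compound 1 to compound 3 (0.04 log units; within the scatter) and it is expected to stay within the scatter. For compound 3 the expected value is 6500 nM with an estimated range from 2500 nM to 17000 nM on measurement.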

Compound 3, half-maximal inhibitory concentration: 10500 nM
Estimate against measurement, compound 3: 1.6-fold (0.21 log units) below, and the stated range covers the measured number.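

In this assay, replacing the 4-methoxyphenyl with the 4-fluorophenyl gives a 1.5-fold higher number from compound 1 to compound 3 (0.17 log units; within the scatter), so this place on the ring accepts the exchange without a change that can be told from the usual scatter. Within the data shown here, this is the first measured step at this position, since the earlier pair differed only at another place, and it shows that methoxy, with its hydrogen-bond acceptor, can leave while the read-out stays within the scatter of compound 1. Unlike the hydroxy change, which ended at a limit for compound 2 and not at a number, this exchange keeps the read-out on a measurable scale: the limit of > 20000 nM in this assay, at which 1 of the 3 values shown sits.

The compounds shown leave open whether any other group at this place, such as an amine, a carboxylic acid, a trifluoromethyl or a longer chain, would move the number beyond the scatter in either direction. They also leave open whether fluoro in place of methoxy would give a similar step in a compound that carries the hydroxy group of compound 2.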